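Sulfanyl purine ribosides against the nucleoside transporter

This account rests on a few compounds, and the source may have more. Where it says the series, first, only, none or still open, it means among the compounds named here.

Measured so far:
compound 1 `O=[N+]([O-])c1ccc2c(c1)CN(c1ncnc3c1ncn3[C@@H]1O[C@H](CO)[C@@H](O)[C@H]1O)CC2` with 5.5 nM
compound 2 `CC(C)Sc1nc(N)nc2c1ncn2[C@@H]1O[C@H](CO)[C@@H](O)[C@H]1O` with 191000 nM
compound 3 `OC[C@H]1O[C@@H](n2cnc3c(CSc4ccccc4Br)ncnc32)[C@H](O)[C@@H]1O` with 2400 nM

Three ribosides with a shared core have been examined in an assay on isolated protein for binding affinity to Equilibrative nucleoside transporter 1 (Homo sapiens); a higher number here means a weaker inhibitor, a lower number a stronger inhibitor. Compound 1 gives 5.5 nM, the lowest number of the three. Compound 2 gives 191000 nM, the highest. Compound 3 gives 2400 nM and stands second highest of the three numbers: its nearest neighbour is compound 2, whose number lies far higher, beyond the scatter, and its furthest is compound 1, whose number lies far lower, again beyond the scatter.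

Compound 4 `OC[C@H]1O[C@@H](n2cnc3c(CSc4ccc(I)cc4)ncnc32)[C@H](O)[C@@H]1O` has not yet been measured in this assay. It differs from compound 3 in one place, (4-iodophenyl in place of 2-bromophenyl on a sulfur). Among the measured compounds shown here, no measured pair in this set shows a change of this kind, so the expectation rests on compound 3 alone and on the wide spread of numbers already seen across the series.

Compound 4 is expected to reach a lower number than compound 3, with a step of roughly a 6.0-fold lower number from compound 3 to compound 4 (0.78 log units; beyond the scatter) estimated, beyond the scatter, though the direction is uncertain. The estimate for compound 4 in this assay is 400 nM, with a range from 60 nM to 3000 nM.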

Compound 4, half-maximal inhibitory concentration: 69.2 nM
Compound 4: middle estimate off by 5.8-fold (0.76 log units), on the high side, within the range that was stated.
By their numbers in this assay, from the lowest: compound 1; then compound 4; then compound 3; then compound 2.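

In this assay, among the compounds shown here, replacing 2-bromophenyl with 4-iodophenyl on a sulfur gives a 35-fold lower number from compound 3 to compound 4 (1.54 log units; beyond the scatter), the first step in this set between compounds that differ in one place. It shows that the aryl group on this sulfur strongly affects the number: one halogenated phenyl replaces another, with the same count of heavy atoms, no hydrogen-bond donors or acceptors on either group and no net charge, yet the step is large and lies beyond the scatter. Nothing available explains why this exchange has so large an effect.

The step changes both the halogen and its place on the ring, and the compounds shown do not separate these two contributions, so it remains open how much of the step belongs to each. Also open, on these data alone, is how this position would respond to a phenyl group carrying no halogen, or to a methoxy group or a carboxylic acid on the ring, and whether a longer chain between the sulfur and the ring would keep the lower number seen for compound 4.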